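The compounds below may be only part of what the source reports. "The series", "measured", "known", "first", "only" and "open" are said of these compounds alone.

Two compounds sharing one core have been measured in a functional assay on CHO-K1 cells for agonist activity at Glucose-dependent insulinotropic receptor (Homo sapiens), read by a luciferase reporter, with a stated time of 5 h; on this read-out lower numbers stand for an effect already at smaller amounts and higher numbers for an effect only at larger amounts of compound:

compound 1 `CCCS(=O)(=O)N1CCN(c2ccc(OCC3CCN(C(=O)NC(C)(C)C)CC3)cn2)CC1` gives 800 nM;
compound 2 `CCCS(=O)(=O)N1CCN(c2ccc(OCC3CCN(C(=O)C(F)F)CC3)cn2)CC1` gives 2100 nM.

Within the data shown here, compound 2 stands highest of the two numbers; its nearest neighbour is compound 1, and the single step between them, a 2.6-fold higher number from compound 1 to compound 2 (0.42 log units; beyond the scatter), replaces (tert-butyl)amino with difluoromethyl on the carbonyl carbon. Compound 3 `CCCS(=O)(=O)N1CCN(c2ccc(OCC3CCN(C(=O)N4CCOCC4)CC3)cn2)CC1` is the next compound, differing from compound 2 by morpholin-4-yl in place of difluoromethyl on a carbonyl carbon. Among the measured compounds shown here, only the step from compound 1 to compound 2 bears on this change, and it was modest. Since compound 3 returns to a urea-type carbonyl, as in compound 1, but without the hydrogen-bond donor of compound 1, a move part of the way back toward the number of compound 1 is expected. Compound 3 is therefore estimated at 1200 nM, within 500 nM to 3500 nM, a step of a 1.8-fold lower number from compound 2 to compound 3 (0.24 log units; within the scatter) that is expected to sit near the edge of the scatter.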

Compound 3, half-maximal effective concentration: > 10000 nM
Compound 3: a limit, no number; the forecaster's own chance of this, stated with the estimate: 5%; middle value at least 8.3-fold (0.92 log units) away from the limit.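

In this assay, compound 3 gives a limit and not a number: the limit of > 10000 nM in this assay, at which 1 of the 3 values shown sits. Read as bounds, the change on the carbonyl carbon gives an at least 4.7-fold higher number from compound 2 to compound 3 (0.67 log units; beyond the scatter), and the comparison with the (tert-butyl)amino group gives an at least 12-fold higher number from compound 1 to compound 3 (1.09 log units; beyond the scatter), a large step. The place therefore responds far more strongly than the first modest step showed, and a nitrogen-linked group on the carbonyl carbon does not by itself keep the activity, since (tert-butyl)amino and morpholin-4-yl are both attached through nitrogen yet sit far apart.

The compounds shown do not separate the ring from the missing amide hydrogen, or from the ring oxygen, as the feature that matters. A piperidin-1-yl or dimethylamino group on the same carbonyl carbon would bear on this, as would a cyclohexylamino group.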